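The compounds below may be only part of what the source reports. "The series", "measured", "known", "first", "only" and "open" are said of these compounds alone.

Compound 1, `CCCCCCCCC(CCO)n1cnc2c(N)nc(Cl)nc21`, and compound 2, `CCCCCCCCCC(CCO)n1cnc2c(N)nc(Cl)nc21`, share one core and differ in a single place. In a functional assay on SW480 cells (Homo sapiens) for antiproliferative activity, read by MTT assay, with a stated time of 48 h (a lower number here means a stronger inhibitor, a higher number a weaker inhibitor), compound 1 gives 13100 nM, and compound 2 gives 12200 nM. The change between them is methyl in place of hydrogen on a saturated chain carbon, nine bonds along the chain from an aromatic nitrogen, and it made a 1.1-fold lower number from compound 1 to compound 2 (0.03 log units; within the scatter).

Compound 3, `CCCCCCCCCCC(CCO)n1cnc2c(Cl)ncnc21`, carries a different core; how that core differs from the core of compound 1 is not broken down here. In this assay, among the compounds with values here, compound 3 gives 3160 nM, the lowest of the three numbers so far.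

Compound 4, `CCCCCCCCCCCC(CCO)n1cnc2c(Cl)ncnc21`, has not yet been measured. It differs from compound 3 by methyl in place of hydrogen on a saturated chain carbon, ten or more bonds along the chain from an aromatic nitrogen. Within the data shown here, this is the same kind of change as the one from compound 1 to compound 2, but its place along the chain is not identical, as the two descriptions of the change show.

Because a 1.1-fold lower number from compound 1 to compound 2 (0.03 log units; within the scatter) stayed within the scatter, the expected step for compound 4 is a 1.1-fold lower number from compound 3 to compound 4 (0.04 log units; within the scatter). Compound 4 is estimated at 2900 nM in this assay, with an expected range from 1200 nM to 7000 nM.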

Compound 4, half-maximal inhibitory concentration: 5290 nM
The estimate for compound 4 lay 1.8-fold (0.26 log units) below the measured number, within the range that was stated.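

In this assay, the added methyl at the far end of the chain gave a 1.7-fold higher number from compound 3 to compound 4 (0.22 log units; within the scatter), so on this core the step cannot be told apart from repeat-measurement noise. Set beside the same change on the other core, the two steps do not clearly differ: the same change on two cores in this assay, a 1.1-fold lower number (0.03 log units; within the scatter) from compound 1 to compound 2 and a 1.7-fold higher number (0.22 log units; within the scatter) from compound 3 to compound 4, 1.8-fold (0.25 log units) apart, within the scatter of two such steps This shows that, for these two pairs, the change behaved alike on both cores, with neither step moving the number beyond the scatter, but it does not show that chain length is irrelevant in this series, since each core offers only one step, the two steps sit at different places along the chain, and a small real effect could hide within the scatter.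

The compounds shown leave open whether a much longer chain, or an amine or a carboxylic acid on the chain, would produce a step beyond the scatter. Within the data shown here, they also leave open how much of the gap between the cores belongs to the core alone, since no two compounds here have different cores with identical chains.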